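From a Furan to a Pyrimidine on the Shared Core

The compounds below may be only part of what the source reports. "The series", "measured", "known", "first", "only" and "open" are said of these compounds alone.

For the measured compounds named here, compound 1 `c1coc(-c2ccccc2NCC2=NCCN2)c1` is the only compound here with a full number: in a functional assay for activation of Alpha-1D adrenergic receptor (Homo sapiens) (on this read-out lower numbers stand for an effect already at smaller amounts and higher numbers for an effect only at larger amounts of compound), compound 1 gives 16.2 nM. Compound 2 `Cc1ncc(-c2ccccc2NCC2=NCCN2)o1` carries 2-methyl-1,3-oxazol-5-yl in place of furan-2-yl on an aromatic carbon. In this assay compound 2 gives only a limit, < 5020 nM. The step that the limit leaves unreadable from compound 1 to compound 2 therefore has no readable size (the limit of < 5020 nM in this assay, at which 1 of the 2 values shown sits). Compound 3 `c1cnc(-c2ccccc2NCC2=NCCN2)nc1` differs from compound 1 by pyrimidin-2-yl in place of furan-2-yl on an aromatic carbon. Going by the values given here, no measured step offers a readable size for such a swap, so the expectation rests on the structural change alone. For compound 3 in this assay the estimate is 120 nM, between 15 nM and 1500 nM, an expected step of a 7.4-fold higher number from compound 1 to compound 3 (0.87 log units; beyond the scatter).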

Compound 3, half-maximal effective concentration: 81.3 nM
Beside the measured number, compound 3's estimate is 1.5-fold (0.17 log units) above it; measured number inside the range.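

In this assay, for the compounds shown here, pyrimidin-2-yl in place of furan-2-yl gives a 5.0-fold higher number from compound 1 to compound 3 (0.70 log units; beyond the scatter), the first step of readable size at this position. So a six-membered aromatic ring on this aromatic carbon still gives a full number, and the change from the five-membered furan-2-yl costs only a modest step. The steps involving compound 2 cannot be read, since compound 2 gives only a limit: the limit of < 5020 nM in this assay, at which 1 of the 3 values shown sits.

As far as these compounds go, how a pyridin-2-yl ring, a plain phenyl ring or a simple amine at this position would read stays open. So does whether the result for pyrimidin-2-yl extends to any other six-membered ring.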